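The source may hold more compounds than are shown below. What is called first, only, known or untested is meant among the compounds shown, and "the series" means these compounds.

Compound 1 `COc1cc2c(Oc3ccc(NC(=O)N/N=C/c4ccc([N+](=O)[O-])cc4)cc3F)ccnc2cc1OCCCN1CCCC1`: 470 nM
Compound 2 `COc1cc2c(Oc3ccc(NC(=O)N/N=C/c4ccc(C(F)(F)F)cc4)cc3F)ccnc2cc1OCCCN1CCCC1`: 1300 nM
Compound 3 `COc1ccc(/C=N/NC(=O)Nc2ccc(Oc3ccnc4cc(OCCCN5CCCCC5)c(OC)cc34)c(F)c2)c(OC)c1`: 1990 nM

These three share one core and differ in the aryl group hanging from the imine carbon. In a functional assay on MKN-45 cells (Homo sapiens) for cytotoxicity, read by MTT assay, with a stated time of 72 h (on this read-out higher numbers stand for weaker inhibition and lower numbers for stronger inhibition), compound 3 gives 1990 nM; its number and that of compound 2 lie within the scatter of each other, while compound 1 sits beyond the scatter at a lower number. Compound 4 `COc1cc2c(Oc3ccc(NC(=O)N/N=C/c4cccs4)cc3F)ccnc2cc1OCCCN1CCCCC1` differs from compound 3 in one place: thiophen-2-yl in place of 2,4-dimethoxyphenyl on a carbon with a double bond to nitrogen. For the measured compounds named here, the only measured step, a 2.8-fold higher number from compound 1 to compound 2 (0.44 log units; beyond the scatter), concerns a substituent on that same aryl ring rather than a swap of the ring itself, so it bears only loosely on this change. Going by the values given here, with no closer precedent, compound 4 is expected near the middle of the measured range, with a 1.7-fold lower number from compound 3 to compound 4 (0.22 log units; within the scatter), giving an estimate of 1200 nM (range 400 nM to 4000 nM).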

Compound 4, half-maximal inhibitory concentration: 740 nM
Compound 4: the middle estimate sits 1.6-fold (0.21 log units) above what was measured; the measured number falls inside the stated range.
By their numbers in this assay, from the lowest: compounds 1, 4, 2 and 3 (each within the scatter of the next, the first and the last beyond it).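

In this assay, for the compounds shown here, this is the first step that replaces the whole aryl ring on the carbon with a double bond to nitrogen while the rest of the molecule stays fixed; the earlier step changed only a substituent on that ring. Thiophen-2-yl in place of 2,4-dimethoxyphenyl gives a 2.7-fold lower number from compound 3 to compound 4 (0.43 log units; beyond the scatter), so the smaller ring without methoxy groups is tolerated at this position. Nothing available explains this step.

Going by these compounds, whether furan-2-yl or an unsubstituted phenyl ring would behave like thiophen-2-yl remains open.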